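Fluorine shift on the benzyl group, compound 2 to compound 3

A few compounds are considered here, and "the series" means these few. Any claim that something is new, unique, unknown or untested is made for them only; others in the source may bear on it.

In a functional assay on SW480 cells (Homo sapiens) for cytotoxicity, read by MTT assay, with a stated time of 48 h (on this read-out lower numbers stand for stronger inhibition and higher numbers for weaker inhibition), compound 1 `O=c1ccoc2cc(OCc3cn(Cc4cccc(Br)c4)nn3)ccc12` gives > 100000 nM, which is a limit and not a number. Compound 2 `O=c1ccoc2cc(OCc3cn(Cc4cccc(F)c4)nn3)ccc12` gives > 100000 nM, which is also a limit. Compound 2 therefore has no numerical position in the series, and the evidence so far is the limit of > 100000 nM in this assay, at which 2 of the 2 values shown sit.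

Compound 3 `O=c1ccoc2cc(OCc3cn(Cc4ccc(F)cc4)nn3)ccc12` has 4-fluorophenyl in place of 3-fluorophenyl on a saturated chain carbon bound to an aromatic nitrogen.

Within the data shown here, the only measured step that bears on this change is a step that the two limits leave unreadable from compound 1 to compound 2, with fluoro in place of bromo on an aromatic carbon. It carries no usable size, so no step beyond the scatter is expected in this assay, and a further limit is the likeliest report. The estimated change is a number no higher from compound 2 to compound 3 (the limit leaves the size open). For compound 3 the estimate is 100000 nM, with an expected range of 40000 nM to 200000 nM.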

Compound 3, half-maximal inhibitory concentration: 11200 nM
Beside the measured number, compound 3's estimate is 8.9-fold (0.95 log units) above it; measured number outside the range, below it.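

In this assay, the series now has a number rather than only limits, and exchanging 3-fluorophenyl for 4-fluorophenyl alone gives an at least 8.9-fold lower number from compound 2 to compound 3 (0.95 log units; beyond the scatter). Compounds 2 and 3 have the same atoms joined differently, so in this pair the arrangement of the fluorophenyl group, not its atom content, separates a limit from a number. The exchange of 3-bromophenyl for 4-fluorophenyl gives an at least 8.9-fold lower number from compound 1 to compound 3 (0.95 log units; beyond the scatter), while the step between the other two compounds cannot be read, and the limit remains the commonest report: the limit of > 100000 nM in this assay, at which 2 of the 3 values shown sit.

The compounds shown leave open whether 4-bromophenyl or 4-chlorophenyl would also give a number, or whether this result belongs to 4-fluorophenyl alone. They also leave open how 2-fluorophenyl or an unsubstituted benzyl group would read out on the same core.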